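The compounds below may be only part of what the source reports. "The series", "measured", "known", "first", "only" and "open" are said of these compounds alone.

Measured compounds:
Compound 1, `Cc1cccc(C(=O)N2CCCC(C(=O)Nc3ccc(Cl)cc3)C2)c1`: 0%
Compound 2, `O=C(Nc1cccc([N+](=O)[O-])c1)C1CCCN(C(=O)c2cc(C(F)(F)F)cc(C(F)(F)F)c2)C1`: 9%
Compound 3, `O=C(Nc1cccc(Oc2ccccc2)c1)C1CCCN(C(=O)c2cc(C(F)(F)F)cc(C(F)(F)F)c2)C1`: 1%

The three measured compounds share a core and differ in the groups at either end of it. In an ADME assay on PC-3 cells (Homo sapiens) for cytotoxicity, read by WST assay, tested at 100 uM (on this read-out lower numbers stand for less inhibition and higher numbers for more inhibition at the one concentration tested (going by the name of the read-out)), compound 1 gives 0%, compound 2 gives 9%, and compound 3 gives 1%. Compound 1 sits at the low end of these numbers, and both compound 3 and compound 2 lie within the scatter of it, so the three cannot be told apart on this read-out. Going by the values given here, the only single-point step among them, a number 8 percentage points lower from compound 2 to compound 3 (within the scatter), was likewise within the scatter.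

Compound 4, `Cc1nc(-c2cccc(C(=O)N3CCCC(C(=O)Nc4ccc(Cl)cc4)C3)c2)no1`, has not yet been measured. It differs from compound 1 by 5-methyl-1,2,4-oxadiazol-3-yl in place of methyl on an aromatic carbon. Among the compounds with values here, no measured step touches this part of the core, so nothing among the measured compounds speaks directly to it; what is known is that every change tried so far left the read-out near zero. On that basis a step of a number 3 percentage points higher from compound 1 to compound 4 (within the scatter) is expected, which is to say none beyond the scatter. Compound 4 is therefore estimated at 3%, within a range from 0% to 15%.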

Compound 4, a percentage reported as inhibition, at one concentration (the size of the read-out at that concentration, not a potency): 0%
The estimate for compound 4 lay 3 percentage points above the measured number; the range from low to high includes it.
By their numbers in this assay, from the lowest: compounds 1, 4, 3 and 2 (each within the scatter of the next).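

The replacement is the first change shown at this aromatic carbon, meta to a large group, and in this assay it gives no change at the digits printed from compound 1 to compound 4 (within the scatter) for a much larger group. Here 6 heavy atoms enter where 1 leaves, bringing one five-membered aromatic ring with 3 hetero atoms and 3 hydrogen-bond acceptors, and the read-out still stays within the scatter, so the number stays level across this change in size and make-up at the one concentration tested. Nothing measured offers an explanation for this outcome.

Whether any other group at this carbon would move the number beyond the scatter stays open, since an amine, a carboxylic acid or a longer alkyl chain is not among the compounds shown. Also open, going by these compounds, is whether 5-methyl-1,2,4-oxadiazol-3-yl would read the same way on a compound with different groups at the two ends of the shared core, such as compound 2 or compound 3.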